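This account rests on a few compounds, and the source may have more. Where it says the series, first, only, none or still open, it means among the compounds named here.

Measured compounds:
compound 1 `COc1cc(-c2nn(-c3cccc(NC(=O)c4cccc(C(F)(F)F)c4)c3)cc2-c2ccncc2)ccc1Cl` with 2010 nM in a functional assay on CAKI-1 cells (Homo sapiens) for inhibition, read by sulforhodamine B assay, with a stated time of 48 h; a higher number here means a weaker inhibitor of growth, a lower number a stronger inhibitor of growth
compound 2 `COc1cc(-c2nn(-c3cccc(NC(=O)Nc4ccc(Cl)c(Cl)c4)c3)cc2-c2ccncc2)ccc1Cl` with 1120 nM in this assay

Compound 2 has the lowest of the two numbers shown, though its nearest neighbour, compound 1, sits within the scatter: the step of a 1.8-fold lower number from compound 1 to compound 2 (0.25 log units; within the scatter) does not separate them. Compound 3 `COc1cc(-c2nn(-c3cccc(NC(=O)Nc4cccc(C(F)(F)F)c4)c3)cc2-c2ccncc2)ccc1Cl` keeps the urea of compound 2 and carries 3-(trifluoromethyl)phenyl in place of 3,4-dichlorophenyl on an amide-type nitrogen. Going by the values given here, only one measured step bears on this change, the step of a 1.8-fold lower number from compound 1 to compound 2 (0.25 log units; within the scatter), which swapped the same two aryl groups while also turning an amide into a urea, and it stayed within the scatter. Since the aryl swap itself left no mark there, compound 3 is expected to land close to compound 2, with no step beyond the scatter in either direction. The expected step is a 1.3-fold higher number from compound 2 to compound 3 (0.13 log units; within the scatter). Compound 3 is therefore estimated at 1500 nM in this assay, within a range of 600 nM to 3800 nM.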

Compound 3, concentration for 50% growth inhibition: 1030 nM
Beside the measured number, compound 3's estimate is 1.5-fold (0.16 log units) above it, and the stated range covers the measured number.
By their numbers in this assay, from the lowest: compounds 3, 2 and 1 (each within the scatter of the next).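

Compound 3 separates the two changes that were combined in the earlier step. With the urea held fixed in this assay, 3-(trifluoromethyl)phenyl in place of 3,4-dichlorophenyl on the amide-type nitrogen gives (a 1.1-fold lower number from compound 2 to compound 3 (0.04 log units; within the scatter)), while with the 3-(trifluoromethyl)phenyl group held fixed, the urea in place of the amide gives (a 2.0-fold lower number from compound 1 to compound 3 (0.29 log units; within the scatter)), so neither change taken alone moves the number beyond the scatter. Nothing available explains why these values stay so close.

Going by these compounds, all three compounds carry a halogen-bearing phenyl group at this end, so it remains open whether a different group there, such as a cyclohexyl ring or a phenyl ring bearing a carboxylic acid, would give a step beyond the scatter. The shared core is also the same throughout, leaving the effect of any change to it unknown.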